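Working notes on compound 3: allyl in place of tert-butyl

A few compounds are considered here, and "the series" means these few. Any claim that something is new, unique, unknown or untested is made for them only; others in the source may bear on it.

Measured so far:
- compound 1 `CSc1ccc(Cc2nn(C(C)(C)C)c(=O)c3ccccc23)cc1`; in a functional assay on aorta with Alpha-1D adrenergic receptor (Rattus norvegicus) as the target (on this read-out lower numbers stand for an effect already at smaller amounts and higher numbers for an effect only at larger amounts of compound), compound 1 gives > 100000 nM, a limit of the assay and not a number.
- compound 2 `CC(C)(C)n1nc(Cc2ccc(Cl)cc2)c2ccccc2c1=O`; in this assay compound 2 gives > 100000 nM, likewise a limit and not a number.

Compound 2 therefore stands at the limit, as summarised in the limit of > 100000 nM in this assay, at which 2 of the 2 values shown sit. Among the measured compounds shown here, the only measured step, a step that the two limits leave unreadable from compound 1 to compound 2, cannot be read in size from two limits.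

Compound 3 `C=CCn1nc(Cc2ccc(Cl)cc2)c2ccccc2c1=O` has not yet been measured in this assay. It differs from compound 2 by allyl in place of tert-butyl on an aromatic nitrogen. For the measured compounds named here, no measured step touches this aromatic nitrogen; the one step available concerns a chloro for methylsulfanyl exchange on an aromatic carbon and is itself unreadable, so the numbers give no direction for the change in this assay. The step of a number no higher from compound 2 to compound 3 (the limit leaves the size open) is accordingly expected to stay within the scatter. Compound 3 is estimated at 100000 nM in this assay, with a range from 20000 nM to 300000 nM, and most probably it will again be reported only as a limit.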

Compound 3, half-maximal effective concentration: 2600 nM
Compound 3: the middle estimate sits 38-fold (1.59 log units) above what was measured, outside the stated range (below it).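

Among the compounds shown here, the aromatic nitrogen is the first place where a change can be read: in this assay, allyl in place of tert-butyl gives an at least 38-fold lower number from compound 2 to compound 3 (1.58 log units; beyond the scatter). From the compounds shown here alone, the step starts from a limit of the assay, so its full size stays open, but it shows that the core shared by compound 2 and compound 3 can give a number on this read-out when allyl replaces tert-butyl. Compound 3 is the only compound shown with a number, and the others stand at a limit of the assay: the limit of > 100000 nM in this assay, at which 2 of the 3 values shown sit.

This single step cannot separate the double bond of allyl from the loss of the tert-butyl branching, and a propyl or methyl group on this aromatic nitrogen would be needed to tell them apart. Going by these compounds, the step from methylsulfanyl to chloro on the aromatic carbon cannot be read from its two limits, so whether that exchange matters with allyl on the nitrogen stays open, as does the effect of a longer chain or an amine at the nitrogen.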